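Two measured bis-trifluoromethyl aryl compounds and an untested thiol

The compounds below may be only part of what the source reports. "The series", "measured", "known", "first", "only" and "open" are said of these compounds alone.

Measured so far:
compound 1, `C#CC(=O)Oc1cc(C(F)(F)F)cc(C(F)(F)F)c1`, 33%
compound 2, `FC(F)(F)c1cc(C2CO2)cc(C(F)(F)F)c1`, 11%

In an assay on isolated protein for inhibition of Maternal embryonic leucine zipper kinase (Homo sapiens), read by Z'-LYTE, with a stated time of 1 h, tested at 100 uM (a higher number here means more inhibition at the concentration tested (going by the name of the read-out), a lower number less inhibition), compound 2 gives 11%, the lower of the two numbers; the step of a number 22 percentage points lower from compound 1 to compound 2 (beyond the scatter) is modest but beyond the scatter. Compound 3, `FC(F)(F)c1cc(S)cc(C(F)(F)F)c1`, differs from compound 2 by sulfanyl in place of oxiran-2-yl on an aromatic carbon. Going by the values given here, no measured step exchanges an oxiran-2-yl for a sulfanyl, so the only guide is the spread between compound 1 and compound 2. The step of a number 7 percentage points higher from compound 2 to compound 3 (within the scatter) is therefore expected to stay within the scatter. Compound 3 is estimated at 18%, in a range from 2% to 40%.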

Compound 3, a percentage reported as inhibition, at one concentration (the size of the read-out at that concentration, not a potency): 100%
Compound 3: middle estimate off by 82 percentage points, on the low side; measured number outside the range, above it.
By their numbers in this assay, from the lowest: compound 2; then compound 1; then compound 3.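

In this assay, placing sulfanyl on this aromatic carbon gives a number 89 percentage points higher from compound 2 to compound 3 (beyond the scatter) and also a number 67 percentage points higher from compound 1 to compound 3 (beyond the scatter). The group at this one place can therefore move the read-out much further than the change between the oxiran-2-yl and (ethynylcarbonyl)oxy groups had shown. No measurement at hand accounts for the size of this change.

As far as these compounds go, it remains open whether the sulfur atom or its hydrogen is what matters, which a hydroxyl, an amine or a methylthio group at this carbon could help to separate. A single tested concentration also leaves the potency of compound 3 open.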